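This account rests on a few compounds, and the source may have more. Where it says the series, first, only, none or still open, it means among the compounds named here.

Compound 1 `CNC(=O)[C@@]12C[C@@H]1[C@@H](n1cnc3c(NC)nc(C#Cc4ccccc4)nc31)[C@H](O)[C@@H]2O` was tested in an assay on CHO cells for displacement of a labelled ligand from adenosine receptor A1 (Homo sapiens), read by scintillation counting, with a stated time of 60 min, tested at 10 uM (on this read-out lower numbers stand for less inhibition and higher numbers for more inhibition at the one concentration tested (going by the name of the read-out)), where compound 1 gives 18%. Compound 2 `CNC(=O)[C@@]12C[C@@H]1[C@@H](n1cnc3c(NC)nc(C#Cc4ccccc4F)nc31)[C@H](O)[C@@H]2O` gives 20% in this assay, and compound 3 `CNC(=O)[C@@]12C[C@@H]1[C@@H](n1cnc3c(NC)nc(C#Cc4cccc(C(F)(F)F)c4)nc31)[C@H](O)[C@@H]2O` gives 10%. On these numbers compound 1 stands second highest of the three. The nearest step is a number 2 percentage points higher from compound 1 to compound 2 (within the scatter) and the furthest is a number 8 percentage points lower from compound 1 to compound 3 (within the scatter); both lie within the scatter, as does a number 10 percentage points lower from compound 2 to compound 3 (within the scatter). Compound 4 `CNC(=O)[C@@]12C[C@@H]1[C@@H](n1cnc3c(NC)nc(C#Cc4cc(C)c(C)o4)nc31)[C@H](O)[C@@H]2O` has not yet been measured. Compared with compound 1, the change is 4,5-dimethylfuran-2-yl in place of phenyl on a triple-bonded carbon. Among the measured compounds shown here, no measured step replaces the phenyl itself; the two steps that alter it, adding fluoro or trifluoromethyl on an aromatic carbon, stayed within the scatter. The expected step in this assay is therefore a number 1 percentage points lower from compound 1 to compound 4 (within the scatter), none beyond the scatter. Compound 4 is estimated at 17%, with a range from 5% to 30%.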

Compound 4, a percentage reported as inhibition, at one concentration (the size of the read-out at that concentration, not a potency): 15%
The estimate for compound 4 lay 2 percentage points above the measured number; the measured number falls inside the stated range.
By their numbers in this assay, from the lowest: compounds 3, 4, 1 and 2 (each within the scatter of the next).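

Replacing the phenyl ring outright, not just adding to it, leaves the reading in this assay without a real change, with a number 3 percentage points lower from compound 1 to compound 4 (within the scatter) as the direct step, and with a number 5 percentage points higher from compound 3 to compound 4 (within the scatter) and a number 5 percentage points lower from compound 2 to compound 4 (within the scatter) against the substituted phenyl groups. On the triple-bonded carbon, then, a five-membered aromatic ring with a ring oxygen and two methyl groups reads the same as all three phenyl groups. Still open, as far as these compounds go, is whether an amine or a carboxylic acid on this ring, or a plain alkyl chain in its place, would move the number. Nothing given here explains why these four compounds read alike.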